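The source may report more compounds than this note shows. Statements on the series, on what has been measured and on what is new or still open speak of the compounds shown alone.

Compound 1 `CCCn1c(=O)n(CCC(=O)O)c(=O)c2[nH]cnc21`: 21200 nM
Compound 2 `C=CCCn1cnc2c1c(=O)n(C)c(=O)n2CCC`: 16800 nM

Both numbers come from a functional assay (trachea) with Cavia porcellus as the target; on this read-out higher numbers stand for an effect only at larger amounts of compound and lower numbers for an effect already at smaller amounts. Compound 2 holds the lower of the two, but compound 1 stands close by, within the usual scatter, so the two compounds cannot be put in any order of effect; both act only at fairly large amounts in this assay.

Compound 3 `CCCn1c(=O)n(C)c(=O)c2c1ncn2CCOC` has not yet been measured in this assay. It differs from compound 2 in a single place: methoxy in place of vinyl on a saturated chain carbon, two bonds along the chain from an aromatic nitrogen. Among the measured compounds shown here, no measured pair shows what this exchange does, so nothing in the data points to either a gain or a loss. For the measured compounds named here, with only two closely matched compounds to go on, the expected step of a 1.1-fold lower number from compound 2 to compound 3 (0.02 log units; within the scatter) in this assay is none beyond the scatter. Compound 3 is therefore estimated at 16000 nM in this assay, with a range from 5000 nM to 50000 nM.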

Compound 3, half-maximal effective concentration: 36100 nM
Beside the measured number, compound 3's estimate is 2.3-fold (0.35 log units) below it, within the range that was stated.
By their numbers in this assay, from the lowest: compounds 2, 1 and 3 (each within the scatter of the next, the first and the last beyond it).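

Among the compounds shown here, exchanging vinyl for methoxy in this place, which turns but-3-en-1-yl into 2-methoxyethyl, gives the first step that can be read in this assay, with a 2.1-fold higher number from compound 2 to compound 3 (0.33 log units; beyond the scatter). This step is modest, but it shows that the end of this chain is not indifferent: more compound is needed after the exchange, even though both groups count the same number of heavy atoms. The exchange removes a double bond and adds a hydrogen-bond acceptor, but nothing at hand connects either difference to the higher number.

From the compounds shown here alone, whether the double bond or the oxygen matters more remains open, as this single pair changes both at once. Also open, going by these compounds, is how an amine, a hydroxyl group or a longer chain would read at this same place on the shared core.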